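Trading the 3-chlorobenzyl arm of compound 1 for ethyl

The source may hold more compounds than are shown below. What is called first, only, known or untested is meant among the compounds shown, and "the series" means these compounds.

Compound 1 `C=C(Br)C(=O)Nc1ccc(/C=C2\SC(=O)N(Cc3cccc(Cl)c3)C2=O)cc1` was measured in a functional assay on FM3A cells (Mus musculus) for cytotoxicity, read by cell counting, with a stated time of 2 days (a higher number here means a weaker inhibitor, a lower number a stronger inhibitor), where compound 1 gives 6100 nM, the second highest of the three numbers. Its nearest neighbour, compound 2 `Nc1ccc(/C=C2\SC(=O)N(Cc3cccc(Cl)c3)C2=O)cc1`, gives 10000 nM, and the step of a 1.6-fold higher number from compound 1 to compound 2 (0.21 log units; within the scatter) stays within the scatter. Among the measured compounds shown here, compound 3 `C=C(Br)C(=O)Nc1cccc(/C=C2\SC(=O)N(Cc3ccccc3)C2=O)c1` gives 810 nM, a lower number, but it differs from compound 1 in two places, so no single step joins them. Compound 4 `C=C(Br)C(=O)Nc1ccc(/C=C2\SC(=O)N(CC)C2=O)cc1` differs from compound 1 in one place, (methyl in place of 3-chlorophenyl on a saturated chain carbon bound to an amide-type nitrogen in a ring). For the measured compounds named here, no measured step touches this part of the structure, so nothing anchors the direction. The expected step for compound 4 is a 1.3-fold higher number from compound 1 to compound 4 (0.12 log units; within the scatter), not clearly beyond the scatter. Compound 4 is therefore estimated at 8000 nM, with a range of 2500 nM to 25000 nM.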

Compound 4, half-maximal inhibitory concentration: 2300 nM
Compound 4: middle estimate off by 3.5-fold (0.54 log units), on the high side; measured number below the stated range.
By their numbers in this assay, from the lowest: compound 3; then compound 4; then compounds 1 and 2 (each within the scatter of the next).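

In this assay, the change from 3-chlorobenzyl to ethyl gives a 2.7-fold lower number from compound 1 to compound 4 (0.42 log units; beyond the scatter), the first single change shown to move the number beyond the scatter. The 3-chlorophenyl group is therefore not needed for a lower number in this series, since compound 4 lacks it and still reads lower than compound 1. No measured evidence bears on why the number falls. The compounds shown leave open whether the ring or its chlorine accounts for the step. They also leave open how a longer chain or an amine at this position would read.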